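The source may report more compounds than this note shows. Statements on the series, on what has been measured and on what is new or still open speak of the compounds shown alone.

Compound 1 `CN(CCNCc1cn(C(C)(C)C)nn1)CCNc1ccnc2cc(Cl)ccc12` and compound 2 `CN(CCNCc1cn(CCC(=O)Nc2ccccn2)nn1)CCNc1ccnc2cc(Cl)ccc12` share one core and differ only in the group on an aromatic nitrogen. In a functional assay on NCI-H460 cells (Homo sapiens) for antiproliferative activity, read by sulforhodamine B assay, with a stated time of 72 h (a lower number here means a stronger inhibitor, a higher number a weaker inhibitor), compound 1 gives 79000 nM. For compound 2 the assay reports only a limit, > 200000 nM. The step between them is open-ended: an at least 2.5-fold higher number from compound 1 to compound 2 (0.40 log units; beyond the scatter), and its size rests on (the limit of > 200000 nM in this assay, at which 1 of the 2 values shown sits), so only its lower bound is known. Compound 2 thus stands at the weak end of the two values shown, without a number of its own.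

Compound 3 `CN(CCNCc1cn(CCCn2nn[nH]c2=O)nn1)CCNc1ccnc2cc(Cl)ccc12` keeps the core and the chain on the aromatic nitrogen and alters the chain end: a group of 7 heavy atoms (2 carbon, 4 nitrogen, 1 oxygen; one five-membered aromatic ring with 4 hetero atoms) in place of a group of 9 heavy atoms (6 carbon, 2 nitrogen, 1 oxygen; one six-membered aromatic ring with 1 hetero atom), on a saturated chain carbon, two bonds along the chain from an aromatic nitrogen. Among the measured compounds shown here, the only measured step that touches this region is the one from compound 1 to compound 2, which shows the chain end of compound 2 giving a weaker result than tert-butyl; no measured pair compares one chain end against another. No shift beyond the scatter is therefore expected from the new chain end, and the number is expected to stay near the limit. The estimate for compound 3 in this assay is 250000 nM, with a range from 100000 nM to 600000 nM. The expected step is a step that the limit leaves unreadable from compound 2 to compound 3.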

Compound 3, half-maximal inhibitory concentration: > 200000 nM
Compound 3: a limit, no number (the forecaster's own chance of this, stated with the estimate: 65%); the middle value does not contradict the limit.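

In this assay compound 3 also returns only a limit, > 200000 nM, so a second, quite different chain end, a five-membered aromatic ring with 4 hetero atoms in place of (pyridin-2-yl)carbamoyl, ends at the same limit as compound 2. Measured against tert-butyl on the aromatic nitrogen, the new group gives an at least 2.5-fold higher number from compound 1 to compound 3 (0.40 log units; beyond the scatter), which makes tert-butyl the only group shown at this position with a number of its own. The step from compound 2 to compound 3 cannot be read, and no order between the two chain ends can be stated, since the assay gives no number for either of them: the limit of > 200000 nM in this assay, at which 2 of the 3 values shown sit.

Still open, as far as these compounds go, is whether the loss tracks the chain itself or the particular ring at its end, since both chain-bearing compounds sit at the limit and the shared chain is never separated from its end group. A plain propyl group, or the same chain ending in an amine or a carboxylic acid, would help to show whether any chain on this nitrogen can return a number.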